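The compounds below may be only part of what the source reports. "The series", "measured", "known", "first", "only" and "open" are said of these compounds alone.

Compound 1 `COc1ccc(-n2c(=O)n(Cc3cc4cc(Cl)ccc4n3CCCC#N)c3cnccc32)c(F)c1` is tested in an ADME assay on HeLa cells (Homo sapiens) for cytotoxicity, read by ATP content, with a stated time of 3 days (on this read-out higher numbers stand for lower toxicity in this test and lower numbers for higher toxicity in this test), and gives > 50000 nM, which is a limit of the assay rather than a number. Compound 2 `O=c1n(Cc2nc3cnccc3n2CCCCO)c2cnccc2n1C1CC1` gives in this assay the value > 100000 nM, again a limit. Compound 3 `CC(C)CCn1c(Cn2c(=O)n(C3CC3)c3ccncc32)nc2cccnc21` gives in this assay the value > 100000 nM, also a limit.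

Compound 1 therefore stands nowhere on a scale: its result is only a limit, and the same holds for the two other compounds, as the limit of > 100000 nM in this assay, at which 2 of the 3 values shown sit, and the limit of > 50000 nM in this assay, at which 1 of the 3 values shown sits, show. For the measured compounds named here, no step between two measured compounds can be computed here.

Compound 4 `COc1ccc(-n2c(=O)n(Cc3cc4cc(Cl)ccc4n3CCCC#N)c3cnccc32)cc1C` is not yet measured. It differs from compound 1 by 4-methoxy-3-methylphenyl in place of 2-fluoro-4-methoxyphenyl on an aromatic nitrogen. Going by the values given here, with no measured step to lean on and all three known results sitting at a limit, the expected step in this assay from compound 1 to compound 4 is none beyond the scatter, so the estimate is a step that the limit leaves unreadable from compound 1 to compound 4. Compound 4 is thus expected to give about 70000 nM in this assay, in a range from 30000 nM to 150000 nM, most likely reported again only as a limit.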

Compound 4, half-maximal cytotoxic concentration: > 50000 nM
Compound 4: no number, only a limit (the forecaster's own chance of this, stated with the estimate: 85%); the middle value is on the limit's open side.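

In this assay compound 4 gives > 50000 nM, which is a limit and not a number. For the compounds shown here, compound 1 sits at the same limit, so no step between compound 1 and compound 4 can be read. The compounds shown leave open whether 4-methoxy-3-methylphenyl in place of 2-fluoro-4-methoxyphenyl changes the half-maximal cytotoxic concentration at all.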